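The source may report more compounds than this note shows. Statements on the series, on what has been measured and on what is new or still open speak of the compounds shown alone.

Compound 2 `C[C@@H]1[C@@H](O)C(=O)[C@H]2C(C)(C)CCC[C@]2(C)[C@@]1(O)CCc1ccoc1` and compound 1 `CC(=O)O[C@@H]1CC[C@@]2(C)[C@@H](C(=O)[C@H](O)[C@@H](C)[C@]2(O)CCc2ccoc2)C1(C)C` share one core; compound 3 `CCC(=O)[C@H]1O[C@@](CCC2=CC(OC)OC2=O)(OC)[C@@]2(C)CCCC(C)(C)[C@H]12` and compound 4 `CCC(=O)[C@H]1O[C@@](CCC2=CC(OC)OC2=O)(OC)[C@@]2(C)CC[C@@H](OC(C)=O)C(C)(C)[C@H]12` share another, and the difference between the two cores is not broken down here. In a functional assay on RAW264.7 cells (Mus musculus) for inhibition, read by Griess assay, with stated times of 2 h and 18 h (a higher number here means a weaker inhibitor, a lower number a stronger inhibitor), compound 2 gives > 50000 nM, a limit of the assay and not a number. In this assay compound 1 gives > 50000 nM, also a limit. The change from compound 2 to compound 1, (acetoxy in place of hydrogen on a saturated ring carbon), therefore yields a step that the two limits leave unreadable from compound 2 to compound 1 owing to the limit of > 50000 nM in this assay, at which 2 of the 3 values shown sit. In this assay, within the data shown here, compound 3 gives 3900 nM, the only number among the three values. The change acetoxy in place of hydrogen on a saturated ring carbon is the same change applied to the core of compound 3. With no readable precedent, the step is expected to be about a 1.0-fold higher number from compound 3 to compound 4 (0.01 log units; within the scatter). Compound 4 is accordingly estimated at 4000 nM, expected between 1500 nM and 12000 nM.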

Compound 4, half-maximal inhibitory concentration: > 50000 nM
Compound 4: no number, only a limit (the forecaster's own chance of this, stated with the estimate: 10%); middle value at least 12-fold (1.09 log units) from the limit.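

On the core of compound 3, acetoxy in place of hydrogen on a saturated ring carbon weakens inhibition in this assay, giving an at least 12-fold higher number from compound 3 to compound 4 (1.10 log units; beyond the scatter). Compound 4 gives > 50000 nM, which is a limit of the assay and not a number. The step from compound 2 to compound 1 cannot be read, so the series shows a clear effect on one core only and does not show whether the change carries from one core to the other: the limit of > 50000 nM in this assay, at which 3 of the 4 values shown sit.

From the compounds shown here alone, it remains open whether an amine or a longer ester chain on the same saturated ring carbon would keep inhibition close to that of compound 3, at 3900 nM. Also open, going by these compounds, is how either group would read on the core of compound 2.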